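A few compounds are considered here, and "the series" means these few. Any claim that something is new, unique, unknown or untested is made for them only; others in the source may bear on it.

Measured compounds:
- compound 1, `COc1ccc(-c2cc(/C=C/C(=O)c3ccc(N)cc3)[nH]n2)cc1`, 1%
- compound 2, `COc1cc(-c2cc(/C=C/C(=O)c3ccc(N)cc3)[nH]n2)cc(OC)c1OC`, -15%
- compound 3, `COc1cc(-c2cc(/C=C/C(=O)c3ccc(Cl)c(Cl)c3)[nH]n2)cc(OC)c1OC`, 68%

In a functional assay on A549 cells (Homo sapiens) for cytotoxicity, read by sulforhodamine B assay, with a stated time of 48 h, tested at 10 uM (a lower number here means a stronger effect, a higher number a weaker effect of the compound at the concentration tested), compound 1 gives 1% and compound 2 gives -15%, whereas compound 3 gives the highest number of the three; the numbers of compound 1 and compound 2 both lie lower, beyond the scatter. Within the data shown here, the only measured step bearing on a change at the carbonyl carbon is a number 83 percentage points higher from compound 2 to compound 3 (beyond the scatter), a large rise. Compound 4, `COc1ccc(C(=O)/C=C/c2cc(-c3cc(OC)c(OC)c(OC)c3)n[nH]2)cc1OC`, differs from compound 3 in one place: 3,4-dimethoxyphenyl in place of 3,4-dichlorophenyl on a carbonyl carbon. Among the measured compounds shown here, the entering group is neither the 4-aminophenyl of compound 1 and compound 2 nor the 3,4-dichlorophenyl of compound 3, so no measured pair tells how far a dimethoxyphenyl moves the number. For the measured compounds named here, since the only high number belongs to compound 3 because of 68%, the estimate for compound 4 is placed between the measured extremes, with a wide range. Compound 4 is expected to give 40% in this assay, between 5% and 80%. This estimate means a step of a number 28 percentage points lower from compound 3 to compound 4 (beyond the scatter), expected downward but uncertain in size.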

Compound 4, a percentage reported as activity, at one concentration (the size of the read-out at that concentration, not a potency): -43%
Estimate against measurement, compound 4: 83 percentage points above; the measured number lies below the stated range.
By their numbers in this assay, from the lowest: compound 4; then compound 2; then compound 1; then compound 3.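

In this assay, the group on the carbonyl carbon proved able to move the number in the downward direction as well: 3,4-dimethoxyphenyl in place of 3,4-dichlorophenyl gives a number 111 percentage points lower from compound 3 to compound 4 (beyond the scatter). Until now, only a rise had been seen at this place, and 3,4-dimethoxyphenyl in place of 4-aminophenyl now gives a number 28 percentage points lower from compound 2 to compound 4 (beyond the scatter), so the two groups that lie low are also separated from each other, by a modest step on the same core. No measurement shown here offers an explanation for either step.

On these data alone, what a plain phenyl, a 4-hydroxyphenyl or a 3,4-dihydroxyphenyl would give on this carbonyl carbon remains open. Also open, as far as these compounds go, is whether 3,4-dimethoxyphenyl would lower the number in the same way on the core of compound 1.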